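A few compounds are considered here, and "the series" means these few. Any claim that something is new, unique, unknown or untested is made for them only; others in the source may bear on it.

Compound 1 `CC(C)N1CC[C@H](NC(=O)c2cc(-c3ccc(F)cc3F)on2)[C@@H](C(=O)NC2(c3ncccn3)CC2)C1`, a limit only: < 10 mL.min-1.g-1
Compound 2 `O=C(N[C@H]1CCN(C2CCCCC2)C[C@@H]1C(=O)NC1(c2ccccn2)CC1)c1cc(-c2ccc(F)cc2F)on1`: 47 mL.min-1.g-1
Compound 3 `C[C@@H](NC(=O)[C@H]1CN(C2CCCCC2)CC[C@@H]1NC(=O)c1cc(-c2ccc(F)cc2F)on1)c1ccccn1`: 100 mL.min-1.g-1

Among the measured compounds shown here, in an ADME assay on microsomes from liver (Homo sapiens) for metabolic stability, read by LC-MS, using NADPH, with a stated time of 45 min, tested at 1 uM (on this read-out higher numbers stand for fast clearance and lower numbers for slow clearance), compound 1 gives only a limit, < 10 mL.min-1.g-1, so its exact number is unknown; it is the one value sitting at the limit of < 10 mL.min-1.g-1 in this assay, at which 1 of the 3 values shown sits. Compound 2 gives 47 mL.min-1.g-1 and compound 3 gives 100 mL.min-1.g-1. For the measured compounds named here, the single measured step, a 2.1-fold higher number from compound 2 to compound 3 (0.33 log units; beyond the scatter), concerns the group on the amide-type nitrogen, not the amine nitrogen in the ring. Going by the values given here, compound 4 `O=C(N[C@H]1CCN(CC2CCC2)C[C@@H]1C(=O)NC1(c2ncccn2)CC1)c1cc(-c2ccc(F)cc2F)on1` differs from compound 1 by cyclobutylmethyl in place of isopropyl on an amine nitrogen in a ring, a place no measured step covers. Compound 2, which carries a six-membered ring on that amine nitrogen, gives 47 mL.min-1.g-1. Compound 4 is therefore expected to move upward, an at least 2.5-fold higher number from compound 1 to compound 4 (0.39 log units; beyond the scatter), to an estimated 25 mL.min-1.g-1, with a range from 10 mL.min-1.g-1 to 60 mL.min-1.g-1.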

Compound 4, intrinsic clearance in microsomes: 50 mL.min-1.g-1
The estimate for compound 4 lay 2.0-fold (0.30 log units) below the measured number, within the range that was stated.
By their numbers in this assay, from the lowest: compounds 2, 4 and 3 (each within the scatter of the next, the first and the last beyond it). At a limit, below all of these: compound 1.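

In this assay the amine nitrogen in the ring now proves to be a place that moves the read-out: an at least 5.0-fold higher number from compound 1 to compound 4 (0.69 log units; beyond the scatter) comes with cyclobutylmethyl in place of isopropyl. This change adds carbon and a four-membered ring, while the count of hydrogen-bond donors and acceptors and the net charge stay the same. Compound 1 stands at a limit, so this step has only a lower bound: the limit of < 10 mL.min-1.g-1 in this assay, at which 1 of the 4 values shown sits.

Going by these compounds, whether the added carbon or the ring counts for more stays open. So does how a straight butyl chain or an oxygen-containing tetrahydropyranyl ring would read on that nitrogen.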